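Swapping Chloro for Benzyl in a Small Series

The compounds below may be only part of what the source reports. "The series", "measured", "known", "first", "only" and "open" are said of these compounds alone.

For the measured compounds named here, in a functional assay on KG-1 cells (Homo sapiens) for cytotoxicity, read by luminescence and CellTiter-Glo, with a stated time of 3 days (on this read-out lower numbers stand for stronger inhibition and higher numbers for weaker inhibition), compound 2 `N#Cc1ccc(NC(=O)c2cc(Cl)ccc2O)cc1` gives 1860 nM, the only actual number so far. Compound 1 `COc1ccc(O)c(C(=O)Nc2ccc(C#N)cc2)c1` reads > 10000 nM, which is a limit of the assay and not a number. Going by the values given here, the one measured step is an at least 5.3-fold lower number from compound 1 to compound 2 (0.73 log units; beyond the scatter), and it placed chloro where methoxy had been. That same aromatic carbon changes again in compound 3 `N#Cc1ccc(NC(=O)c2cc(Cc3ccccc3)ccc2O)cc1`, which carries benzyl in place of chloro on an aromatic carbon. The earlier step shows that a swap at this carbon can shift the number, but it involved a much smaller incoming group and says little about benzyl. No shift beyond the scatter is therefore expected, though with wide uncertainty in either direction. The estimated step is a 1.1-fold higher number from compound 2 to compound 3 (0.03 log units; within the scatter). For compound 3 the expected value is 2000 nM, with an estimated range from 500 nM to 8000 nM.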

Compound 3, half-maximal inhibitory concentration: 1930 nM
Compound 3: middle estimate off by 1.0-fold (0.02 log units), on the high side; low and high end bracket the measured number.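

Going from the single heavy atom of chloro to the 7 heavy atoms and aromatic ring of benzyl leaves the reading in this assay within the scatter, with a 1.0-fold higher number from compound 2 to compound 3 (0.02 log units; within the scatter). For the compounds shown here, at this carbon, then, the two groups cannot be told apart, however different their size, and methoxy is the one group of the three that stands apart, as benzyl also gives an at least 5.1-fold lower number from compound 1 to compound 3 (0.71 log units; beyond the scatter). Compound 1 reads as a limit and not a number, so the full size of that step stays unknown: the limit of > 10000 nM in this assay, at which 1 of the 3 values shown sits.

From the compounds shown here alone, whether any group at this carbon can bring the number well below the level of compound 2 and compound 3 remains open. Also open, going by these compounds, is how an amine, a carboxylic acid or a longer carbon chain would read here.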